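Swapping Morpholine for Piperidine on a Sulfonyl Group

The source may hold more compounds than are shown below. What is called first, only, known or untested is meant among the compounds shown, and "the series" means these compounds.

Compound 1 `CCCN(CCC)S(=O)(=O)c1ccc(S(=O)(=O)N2CCC[C@@H](C(=O)OCC)C2)cc1` and compound 2 `CCOC(=O)[C@@H]1CCCN(S(=O)(=O)c2ccc(S(=O)(=O)N3CCOCC3)cc2)C1` share one core and differ only at a sulfonyl sulfur. In a functional assay on MIA PaCa-2 cells (Homo sapiens) for inhibition, read by MTT assay, with a stated time of 3 days (a lower number here means a stronger inhibitor, a higher number a weaker inhibitor), compound 1 reaches only the limit of the assay, > 10000 nM. In this assay compound 2 likewise reaches only the limit, > 10000 nM. The step that the two limits leave unreadable from compound 1 to compound 2 cannot be sized, as the limit of > 10000 nM in this assay, at which 2 of the 2 values shown sit, records. Compound 3 `CCOC(=O)[C@@H]1CCCN(S(=O)(=O)c2ccc(S(=O)(=O)N3CCCCC3)cc2)C1` carries the change (piperidin-1-yl in place of morpholin-4-yl on a sulfonyl sulfur). Among the measured compounds shown here, no measured step gives a size for this kind of change, so no shift beyond the scatter can be argued. Compound 3 is expected to sit again near the limit, a step that the limit leaves unreadable from compound 2 to compound 3. The estimate for compound 3 is 15000 nM, with a range from 4000 nM to 60000 nM.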

Compound 3, half-maximal inhibitory concentration: > 10000 nM
Compound 3 ended at the assay's limit; the forecaster's own chance of this, stated with the estimate: 75%; the middle value is on the limit's open side.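

No step can be read among compound 1, compound 2 and compound 3, because all three stop at the same assay limit: the limit of > 10000 nM in this assay, at which 3 of the 3 values shown sit.

The compounds shown leave open whether dipropylamino, morpholin-4-yl and piperidin-1-yl truly differ in this assay, and whether any group on this sulfonyl sulfur gives a readable value.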